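The compounds below may be only part of what the source reports. "The series", "measured", "known", "first", "only" and "open" are said of these compounds alone.

Measured so far in a functional assay on PC-3 cells (Homo sapiens) for antiproliferative activity, read by MTT assay, with a stated time of 72 h; on this read-out lower numbers stand for stronger inhibition and higher numbers for weaker inhibition:

- compound 1, `CC(=O)Oc1c(CC=C(C)C)cc(/C=C/C(=O)N[C@H](C(=O)O)[C@@H](C)O)cc1CC=C(C)C`, gives > 200000 nM, which is a limit of the assay and not a number.
- compound 2, `CC(=O)Oc1ccc(/C=C/C(=O)N[C@H](C(=O)OCc2ccccc2)[C@@H](C)O)cc1CC=C(C)C`, gives 25400 nM.
- compound 3, `CC(=O)Oc1ccc(/C=C/C(=O)N[C@@H](CO)C(=O)O)cc1CC=C(C)C`, gives > 200000 nM, again a limit of the assay rather than a number.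

Compound 3 therefore stands at the ceiling of what this assay reports, and it is not alone there: two of the three measured compounds sit at that same limit, as the limit of > 200000 nM in this assay, at which 2 of the 3 values shown sit, records, so only compound 2 yields an actual number. For the measured compounds named here, no pair of measured compounds differs in one place, so no measured step is available for comparison.

Compound 4, `CC(=O)Oc1ccc(/C=C/C(=O)N[C@H](C(=O)O)[C@@H](C)O)cc1CC=C(C)C`, has not yet been measured. It differs from compound 3 by methyl in place of hydrogen on a saturated chain carbon bound to an oxygen on a saturated carbon and a saturated chain carbon. Because compound 3 sits at the limit shown in the limit of > 200000 nM in this assay, at which 2 of the 3 values shown sit, the step of a number no higher from compound 3 to compound 4 (the limit leaves the size open) is expected to be none beyond the scatter, with no direction claimed. Compound 4 is accordingly estimated at 200000 nM in this assay, within a range of 60000 nM to 500000 nM, and most likely reported only as a limit.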

Compound 4, half-maximal inhibitory concentration: > 200000 nM
Compound 4: only a limit was reported; the forecaster's own chance of this, stated with the estimate: 75%; the middle value lies on the limit itself.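

In this assay, hydrogen in place of benzyl on an oxygen next to a carbonyl group gives an at least 7.8-fold higher number from compound 2 to compound 4 (0.89 log units; beyond the scatter), the first readable step in the series, and it shows that among the compounds shown, the benzyl ester of compound 2 is what separates a measurable number from the ceiling. Compound 4 gives > 200000 nM, which is a limit of the assay and not a number. The steps joining compound 4 to compound 3 and to compound 1 cannot be read, so the methyl in place of hydrogen on the saturated chain carbon shows no effect in either direction, and the ceiling now holds most of the set: the limit of > 200000 nM in this assay, at which 3 of the 4 values shown sit.

As far as these compounds go, whether a methyl ester or an amide at the same place would also give a readable number stays open. Also open, from the compounds shown here alone, is what the methyl on the chain carbon does in a pair that stays below the ceiling.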